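The source may report more compounds than this note shows. Statements on the series, on what has been measured and on what is new or still open speak of the compounds shown alone.

Measured compounds:
- compound 1, `CCOC(=O)CCO/N=C(/c1ccc(OC)c(OC)c1OC)c1cccc2ccccc12` — in a functional assay on A549 cells (Homo sapiens) for inhibition, read by sulforhodamine B assay, with a stated time of 48 h (on this read-out higher numbers stand for weaker inhibition and lower numbers for stronger inhibition), compound 1 gives 19600 nM
- compound 2, `COc1ccc(/C(=N/O)c2cccc3ccccc23)c(OC)c1OC` — in this assay compound 2 gives 13100 nM

Within the data shown here, compound 2 has the lowest of the two numbers, and the only neighbour is compound 1, whose number is higher by a margin within the scatter (a 1.5-fold lower number from compound 1 to compound 2 (0.17 log units; within the scatter)). So the two measured compounds cannot be told apart on potency.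

Compound 3, `CCOC(=O)/C=C/CO/N=C(/c1ccc(OC)c(OC)c1OC)c1cccc2ccccc12`, is not yet measured. It differs from compound 2 in one place: 3-(ethoxycarbonyl)prop-2-en-1-yl in place of hydrogen on an oxygen. Among the measured compounds shown here, this is the same oxygen that carries the 2-(ethoxycarbonyl)ethyl chain in compound 1, so the one measured step that bears on it is the removal of that chain, a 1.5-fold lower number from compound 1 to compound 2 (0.17 log units; within the scatter), which stayed within the scatter. For the measured compounds named here, the chain entering in compound 3 is longer by one carbon and holds a double bond, but with only one comparison of this kind there is no basis to expect anything beyond a small shift toward a higher number.

For compound 3, the expected result in this assay is therefore 18000 nM (estimated range 8000 nM to 45000 nM), a step of a 1.4-fold higher number from compound 2 to compound 3 (0.14 log units; within the scatter) that is expected to remain within the scatter.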

Compound 3, half-maximal inhibitory concentration: 14000 nM
Beside the measured number, compound 3's estimate is 1.3-fold (0.11 log units) above it; measured number inside the range.
By their numbers in this assay, from the lowest: compounds 2, 3 and 1 (each within the scatter of the next).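

In this assay there is a 1.1-fold higher number from compound 2 to compound 3 (0.03 log units; within the scatter) when 3-(ethoxycarbonyl)prop-2-en-1-yl is placed on the oxygen bound to the double-bonded nitrogen, so a second ester-bearing chain at this position also stays within the scatter of the compound with a plain hydroxy group. The two chains cannot be told apart either: there is a 1.4-fold lower number from compound 1 to compound 3 (0.15 log units; within the scatter) on exchanging (ethoxycarbonyl)methyl for 2-(ethoxycarbonyl)ethenyl on the saturated chain carbon, which means that this change in the chain, double bond included, brings no readable shift in this assay. Among these three compounds, then, hydrogen and both ester-bearing chains give numbers that cannot be separated on this oxygen, and no measurement at hand accounts for how close they lie.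

Both chains shown end in an ethyl ester, so it remains open whether a free carboxylic acid, an amine or a much longer chain on this oxygen would move the number beyond the scatter. The shared core is also the same in all three compounds, which leaves open how far changes to it would shift the number.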